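Three Compounds at the Cytotoxicity Limit, a Fourth Awaiting

The source may report more compounds than this note shows. Statements on the series, on what has been measured and on what is new or still open speak of the compounds shown alone.

Compound 1, `OC[C@H]1O[C@@H](n2cnc3c(NCc4ccccc4Cl)ncnc32)[C@H](O)[C@@H]1O`, gives > 166000 nM in an ADME assay on NIH3T3 cells (Mus musculus) for cytotoxicity, with a stated time of 72 h (on this read-out higher numbers stand for weaker inhibition and lower numbers for stronger inhibition), which is a limit of the assay and not a number.
Compound 2, `OC[C@H]1O[C@@H](n2cnc3c(NCc4ccc(Br)cc4)ncnc32)[C@H](O)[C@@H]1O`, gives > 166000 nM in this assay, again a limit.
Compound 3, `OC[C@H]1O[C@@H](n2cnc3c(NCc4ccc(F)c(Cl)c4)ncnc32)[C@H](O)[C@@H]1O`, gives > 166000 nM in this assay, again a limit.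

Compound 2 therefore stands at the limit of the assay, and so do the other two, as the limit of > 166000 nM in this assay, at which 3 of the 3 values shown sit, shows. Because of the limit of > 166000 nM in this assay, at which 3 of the 3 values shown sit, the steps among the three are unreadable: a step that the two limits leave unreadable from compound 1 to compound 2, a step that the two limits leave unreadable from compound 2 to compound 3 and a step that the two limits leave unreadable from compound 1 to compound 3. None of them says whether changing the group on the saturated chain carbon bound to a nitrogen on an aromatic ring moves cytotoxicity at all.

Compound 4, `COc1cccc(CNc2ncnc3c2ncn3[C@@H]2O[C@H](CO)[C@@H](O)[C@H]2O)c1O`, is not yet measured. It differs from compound 2 as follows: 2-hydroxy-3-methoxyphenyl in place of 4-bromophenyl on a saturated chain carbon bound to a nitrogen on an aromatic ring.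

All three measured steps bear on this change in the sense that each swaps the same kind of group in the same place, and each left the value at the limit. No readable step is therefore expected in this assay from compound 2 to compound 4, and the most likely outcome is once more a limit. Compound 4 is expected to give about 200000 nM, between 100000 nM and 400000 nM, in this assay. That estimate means an expected step that the limit leaves unreadable from compound 2 to compound 4.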

Compound 4, half-maximal inhibitory concentration: > 166000 nM
Compound 4 ended at the assay's limit; the forecaster's own chance of this, stated with the estimate: 80%; the middle value is on the limit's open side.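

The steps joining compound 4 to compound 1, compound 2 and compound 3 cannot be read, because in this assay all four compounds stop at the same limit, which is not a number: the limit of > 166000 nM in this assay, at which 4 of the 4 values shown sit. The compounds shown leave open whether any group at this place changes cytotoxicity at all.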